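The compounds below may be only part of what the source reports. "The series", "measured", "known", "first", "only" and "open" are said of these compounds alone.

Measured so far, in a functional assay on NIH3T3 cells (Mus musculus); on this read-out lower numbers stand for an effect already at smaller amounts and higher numbers for an effect only at larger amounts of compound:

Compound 1 `CSCC[C@H](NC(=O)c1ccc(NCc2cncn2Cc2cccc(C)c2)cc1-c1ccccc1)C(=O)O`: compound 1 gives > 10 uM, a limit of the assay and not a number.
Compound 2 `CSCC[C@H](NC(=O)c1ccc(NCc2cncn2Cc2ccc([N+](=O)[O-])cc2)cc1-c1ccccc1)C(=O)O`: compound 2 gives > 10 uM, again only a limit.
Compound 3 `COC(=O)[C@H](CCSC)NC(=O)c1ccc(NCc2cncn2Cc2cccc(C)c2)cc1-c1ccccc1`: compound 3 gives > 10 uM, again only a limit.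

The change from compound 1 to compound 2 is 4-nitrophenyl in place of 3-methylphenyl on a saturated chain carbon bound to an aromatic nitrogen. Its step is a step that the two limits leave unreadable from compound 1 to compound 2, since both ends sit at a limit. The two cores, that of compound 1 and that of compound 3, differ by methyl in place of hydrogen on an oxygen next to a carbonyl group; the step that the two limits leave unreadable from compound 1 to compound 3 is likewise not readable, for the same reason: the limit of > 10 uM in this assay, at which 3 of the 3 values shown sit.

Compound 4 `COC(=O)[C@H](CCSC)NC(=O)c1ccc(NCc2cncn2Cc2ccc([N+](=O)[O-])cc2)cc1-c1ccccc1` has not been measured in this assay. It arises from compound 3 by 4-nitrophenyl in place of 3-methylphenyl on a saturated chain carbon bound to an aromatic nitrogen, which is the same change as from compound 1 to compound 2, made at the same place. No readable step is available from that earlier pair, because the limit of > 10 uM in this assay, at which 3 of the 3 values shown sit, holds for every value shown. For this assay the expected step is therefore a step that the limit leaves unreadable from compound 3 to compound 4, resting only on the fact that compound 1, compound 2 and compound 3 all sit at the limit. Compound 4 is expected to give about 30 uM, most likely again as a limit, with a plausible range from 10 uM to 100 uM.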

Compound 4, concentration for half-maximal effect: > 10 uM
Compound 4 was reported as a limit; the forecaster's own chance of this, stated with the estimate: 85%; the middle value lies beyond the limit too.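

No step can be read from compound 4 in this assay, neither against compound 3 nor against compound 2, since each pair has a limit at both ends: the limit of > 10 uM in this assay, at which 4 of the 4 values shown sit.

Still open, from the compounds shown here alone, is whether 4-nitrobenzyl in place of 3-methylbenzyl, or methyl in place of hydrogen on the oxygen, changes the read-out at all, and what value any of compounds 1, 2, 3 and 4 actually has.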